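The source may report more compounds than this note shows. Statements on the series, on what has been measured and on what is new or still open speak of the compounds shown alone.

Measured in an ADME assay on HepG2 cells (Homo sapiens) for cytotoxicity; a higher number here means that more compound is needed for the effect, a lower number that less compound is needed:
- Compound 1 `COc1cccc(C(=O)NCCNC(=O)[C@H](CC(=O)NC(C)(C)C)NS(=O)(=O)c2ccc(C)cc2)c1`: > 11000 nM
- Compound 2 `Cc1ccc(S(=O)(=O)N[C@@H](CC(=O)NC(C)(C)C)C(=O)NCCNC(=O)c2ccc(F)cc2)cc1`: > 11000 nM
- Compound 3 `Cc1ccc(S(=O)(=O)N[C@@H](CC(=O)NC(C)(C)C)C(=O)NCCNC(=O)NCc2ccccc2)cc1`: > 11000 nM

Compound 3 stands at > 11000 nM, which is a limit of the assay and not a number. It shares this reading with the other measured compounds: the limit of > 11000 nM in this assay, at which 3 of the 3 values shown sit.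

Compound 4 `C#Cc1cccc(C(=O)NCCNC(=O)[C@H](CC(=O)NC(C)(C)C)NS(=O)(=O)c2ccc(C)cc2)c1` differs from compound 3 in one place, with 3-ethynylphenyl in place of benzylamino on a carbonyl carbon.

Three measured steps change the group in that place: a step that the two limits leave unreadable from compound 1 to compound 2, a step that the two limits leave unreadable from compound 1 to compound 3 and a step that the two limits leave unreadable from compound 2 to compound 3. None of them has a readable size, so they give no sign of a change in either direction, and no step beyond the scatter is expected in this assay.

The expected result is a step that the limit leaves unreadable from compound 3 to compound 4.

For compound 4, the estimated value is 15000 nM, with an expected range from 9000 nM to 30000 nM.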

Compound 4, half-maximal effective concentration: > 11000 nM
Compound 4: only a limit was reported; the forecaster's own chance of this, stated with the estimate: 90%; the middle value does not contradict the limit.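

Compound 4 also ends at a limit of the assay rather than a number, so no step from compound 1, compound 2 or compound 3 to it can be read: the limit of > 11000 nM in this assay, at which 4 of the 4 values shown sit.

The compounds shown leave open how much of any of them is needed in this assay, and so whether changing this group makes any difference.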